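From 3-chlorophenyl to 4-(tert-butyl)phenyl

A few compounds are considered here, and "the series" means these few. Any claim that something is new, unique, unknown or untested is made for them only; others in the source may bear on it.

Values measured in an ADME assay on L132 cells (Homo sapiens) for cytotoxicity, read by MTT assay, with a stated time of 48 h (on this read-out higher numbers stand for weaker inhibition and lower numbers for stronger inhibition), are:
- Compound 1 `C/C(=C\CC/C(C)=C/CC[C@@H]1[C@@]2(C)CCC(=O)C(C)(C)[C@H]2CC[C@@]1(C)O)CC/C=C(\C)C(=O)OCc1cn(-c2ccccc2Br)nn1` gives > 150000 nM (a limit, not a number)
- Compound 2 `C/C(=C\CC/C(C)=C/CC[C@@H]1[C@@]2(C)CCC(=O)C(C)(C)[C@H]2CC[C@@]1(C)O)CC/C=C(\C)C(=O)OCc1cn(-c2cccc(Cl)c2)nn1` gives 94200 nM (the only actual number)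

Compound 2 therefore stands alone, with no second number to rank it against. Compound 1 offers only a limit (the limit of > 150000 nM in this assay, at which 1 of the 2 values shown sits).

Compound 3 `C/C(=C\CC/C(C)=C/CC[C@@H]1[C@@]2(C)CCC(=O)C(C)(C)[C@H]2CC[C@@]1(C)O)CC/C=C(\C)C(=O)OCc1cn(-c2ccc(C(C)(C)C)cc2)nn1` carries 4-(tert-butyl)phenyl in place of 3-chlorophenyl on an aromatic nitrogen. Going by the values given here, the only measured step at that nitrogen is an at least 1.5-fold lower number from compound 1 to compound 2 (0.20 log units; that floor lies within the scatter) and it is bounded on one side by a limit. That step swaps one substituted phenyl for another, and its floor does not exceed the scatter, so no step beyond the scatter is expected for compound 3 in this assay and the reading may again be only a limit. The expected change is small, an estimated 1.2-fold higher number from compound 2 to compound 3 (0.07 log units; within the scatter) and no more than that. Compound 3 is expected at 110000 nM (estimated range 50000 nM to 220000 nM).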

Compound 3, half-maximal inhibitory concentration: 65800 nM
Beside the measured number, compound 3's estimate is 1.7-fold (0.22 log units) above it; the measured number falls inside the stated range.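

In this assay, replacing 3-chlorophenyl with 4-(tert-butyl)phenyl on the aromatic nitrogen gives a 1.4-fold lower number from compound 2 to compound 3 (0.16 log units; within the scatter), so the two compounds cannot be told apart on this read-out, even though a carbon-only group of 10 heavy atoms has taken the place of a chlorine-bearing group of 7. What the earlier pair could not show is a step at this nitrogen that clears the scatter: 4-(tert-butyl)phenyl in place of 2-bromophenyl gives an at least 2.2-fold lower number from compound 1 to compound 3 (0.35 log units; beyond the scatter). That step is only a floor because compound 1 is the one compound here recorded as a limit rather than a number: the limit of > 150000 nM in this assay, at which 1 of the 3 values shown sits.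

Going by these compounds, all three groups at this nitrogen are substituted phenyl rings, so it remains open how the cytotoxicity read-out would respond to an amine or a carboxylic acid on that ring, or to a longer alkyl chain in place of it. Nor can these compounds tell whether the bromine itself or its place on the ring sets compound 1 apart, since compound 1 differs from compound 2 and compound 3 in both.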